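Swapping an acylsulfonamide for a carboxymethoxy group

The compounds below may be only part of what the source reports. "The series", "measured", "known", "first", "only" and "open" are said of these compounds alone.

Two compounds share one core. Compound 1 `CC(C)c1onc(-c2c(Cl)cccc2Cl)c1COc1ccc(N(C)Cc2cccc(C(=O)O)c2)c(C(F)(F)F)n1` gives 102% in an assay on isolated protein for agonist activity at Bile acid receptor (Homo sapiens), read by FRET (on this read-out lower numbers stand for smaller maximal responses and higher numbers for larger maximal responses), and compound 2 `CC(C)c1onc(-c2c(Cl)cccc2Cl)c1COc1ccc(N(C)Cc2ccc(C(=O)NS(C)(=O)=O)cc2)c(C(F)(F)F)n1` gives 105%; the two numbers lie within the usual scatter of each other, so neither is set apart. Compound 3 `CC(C)c1onc(-c2c(Cl)cccc2Cl)c1COc1ccc(N(C)Cc2ccc(OCC(=O)O)cc2)c(C(F)(F)F)n1` has not been measured yet; it differs from compound 2 in one place: carboxymethoxy in place of (methylsulfonyl)carbamoyl on an aromatic carbon. Since both measured compounds reach the full reference response, the step from compound 2 to compound 3 is expected to be a number 5 percentage points lower from compound 2 to compound 3 (within the scatter), which is no change beyond the scatter. Compound 3 is therefore estimated at 100%, within 85% to 115%.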

Compound 3, largest response reached (reported as efficacy), in percent of the reference or control that the assay uses: 90%
For compound 3 the middle estimate is 10 percentage points above the measured one; the measured number falls inside the stated range.
By their numbers in this assay, from the lowest: compound 3; then compounds 1 and 2 (each within the scatter of the next).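

In this assay this aromatic carbon proves sensitive to the group it carries: carboxymethoxy in place of (methylsulfonyl)carbamoyl gives a number 15 percentage points lower from compound 2 to compound 3 (beyond the scatter) as a modest step. Taking 4-(carboxymethoxy)phenyl in place of 3-carboxyphenyl gives a number 12 percentage points lower from compound 1 to compound 3 (beyond the scatter) and is also modest, so the full response of the earlier pair does not carry over to every group tried here. Nothing available explains either step. As far as these compounds go, whether a tetrazole or a longer chain ending in a carboxylic acid on this same aromatic carbon would restore the response remains open.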